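The compounds below may be only part of what the source reports. "The series", "measured", "known", "first", "only" and "open" are said of these compounds alone.

Of the compounds shown here, three sharing one core have been measured in a functional assay on L1210 cells (Mus musculus) for antiproliferative activity, with a stated time of 48 h; on this read-out lower numbers stand for stronger inhibition and higher numbers for weaker inhibition. In this test, compound 1 `C=C(Br)C(=O)Nc1ccc(/C=C/C(=O)c2ccccc2)cc1` gives 5000 nM, compound 2 `C=C(Br)C(=O)Nc1ccc(/C=C/C(=O)c2ccc(Cl)cc2)cc1` gives 1100 nM, and compound 3 `C=C(Br)C(=O)Nc1ccc(/C=C/C(=O)c2cccc(OC)c2)cc1` gives 2100 nM. Compound 3 therefore groups with compound 2: a 1.9-fold higher number from compound 2 to compound 3 (0.28 log units; within the scatter) stays within the scatter, whereas a 2.4-fold lower number from compound 1 to compound 3 (0.38 log units; beyond the scatter) goes beyond it.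

The next change gives compound 4 `C=C(Br)C(=O)Nc1ccc(/C=C/C(=O)c2cccs2)cc1`: thiophen-2-yl in place of 3-methoxyphenyl on a carbonyl carbon, (thiophen-2-yl in place of 3-methoxyphenyl on a carbonyl carbon). For the measured compounds named here, no measured compound carries thiophen-2-yl, so no measured step tests this swap directly. The closest guides are two modest steps, a 4.5-fold lower number from compound 1 to compound 2 (0.66 log units; beyond the scatter) with chloro and a 2.4-fold lower number from compound 1 to compound 3 (0.38 log units; beyond the scatter) with methoxy. Compound 4 carries neither group, so its number may drift back towards that of compound 1, 5000 nM. Only a small rise is expected in this assay, probably not clearly beyond the scatter. The expected change is a 1.4-fold higher number from compound 3 to compound 4 (0.15 log units; within the scatter). For compound 4 the estimated value is 3000 nM, with an expected range from 1200 nM to 7000 nM.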

Compound 4, half-maximal inhibitory concentration: 250 nM
Compound 4: the middle estimate sits 12-fold (1.08 log units) above what was measured; measured number below the stated range.
By their numbers in this assay, from the lowest: compound 4; then compounds 2 and 3 (each within the scatter of the next); then compound 1.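

In this assay, for the compounds shown here, the earlier compounds changed only a substituent on the phenyl ring, whereas replacing the whole ring on the carbonyl carbon with thiophen-2-yl has a larger effect, giving an 8.4-fold lower number from compound 3 to compound 4 (0.92 log units; beyond the scatter) and a 4.4-fold lower number from compound 2 to compound 4 (0.64 log units; beyond the scatter) as well as a 20-fold lower number from compound 1 to compound 4 (1.30 log units; beyond the scatter) for the unsubstituted phenyl pair. Compound 4 thus has the lowest number of the four without carrying either chloro or methoxy, so at this position neither group is needed for stronger inhibition. No measurement shown here explains this gain.

The compounds shown cannot separate the role of the sulfur atom from that of the five-membered ring, or show whether the attachment point on the ring matters; furan-2-yl and thiophen-3-yl would address these questions. Going by these compounds, it also remains open whether a chloro or methoxy group on the thiophene would lower the number further.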